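The compounds below may be only part of what the source reports. "The series", "measured", "known", "first", "only" and "open" are said of these compounds alone.

Measured so far:
compound 1, `N#Cc1ccc(Nc2nc(Oc3ccnc4ccccc34)nc(N3CCN(c4ccccc4Cl)CC3)n2)cc1C(F)(F)F`: > 100000 nM
compound 2, `CCN1CCN(c2nc(Nc3ccc(C#N)c(C(F)(F)F)c3)nc(Oc3ccnc4ccccc34)n2)CC1`: > 100000 nM

In a functional assay on DU-145 cells (Homo sapiens) for cytotoxicity, read by sulforhodamine B assay, with a stated time of 48 h (on this read-out lower numbers stand for higher toxicity in this test and higher numbers for lower toxicity in this test), compound 1 gives > 100000 nM, which is a limit of the assay and not a number. Compound 2 gives > 100000 nM in this assay, again a limit rather than a measured number. The step that the two limits leave unreadable from compound 1 to compound 2 cannot be read, since (the limit of > 100000 nM in this assay, at which 2 of the 2 values shown sit). Compound 3, `N#Cc1ccc(Nc2nc(Oc3ccnc4ccccc34)nc(N3CCN(c4ccccc4F)CC3)n2)cc1C(F)(F)F`, is not yet measured; it differs from compound 2 by 2-fluorophenyl in place of ethyl on an amine nitrogen in a ring. Among the measured compounds shown here, the only measured step at the same ring nitrogen is the one from compound 1 to compound 2, and its size is hidden by the two limits, so no direction can be drawn from it. Both measured compounds sit at the limit, and compound 1 carries a 2-chlorophenyl on that ring nitrogen. Compound 3 is therefore expected to sit at the limit as well, with an estimate of 100000 nM and a range of 30000 nM to 300000 nM. The expected step is a number no higher from compound 2 to compound 3 (the limit leaves the size open).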

Compound 3, concentration lethal to 50% of the cells: > 100000 nM
Compound 3: only a limit was reported; the forecaster's own chance of this, stated with the estimate: 85%; the middle value lies on the limit itself.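

With compound 3 the result is again a limit of the assay and not a number, so no step can be read among compound 1, compound 2 and compound 3: the limit of > 100000 nM in this assay, at which 3 of the 3 values shown sit.

The compounds shown leave open how 2-chlorophenyl, ethyl and 2-fluorophenyl on the ring nitrogen rank against one another in this assay.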